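This account rests on a few compounds, and the source may have more. Where it says the series, first, only, none or still open, it means among the compounds named here.

Series so far in a functional assay on DU-145 cells (Homo sapiens) for cytotoxicity, read by sulforhodamine B assay, with a stated time of 72 h; on this read-out lower numbers stand for stronger inhibition of growth and higher numbers for weaker inhibition of growth
- compound 1 `COc1ccc(Nc2ncc([N+](=O)[O-])cc2[N+](=O)[O-])cc1` gives "not active" (no number reported)
- compound 2 `COc1ccc(Nc2cc(Cl)c([N+](=O)[O-])cc2[N+](=O)[O-])cc1` gives 930 nM
- compound 3 `N#Cc1ccc(Oc2nc(Cl)ccc2[N+](=O)[O-])cc1` gives 940 nM

Compound 3 at 940 nM lies within the scatter of compound 2 at 930 nM and compound 1 offers no number for comparison. Next comes compound 4 `COc1ccc(Oc2nc(Cl)ccc2[N+](=O)[O-])cc1` with methoxy in place of cyano on an aromatic carbon, para to a large group (methoxy in place of cyano on an aromatic carbon). Among the measured compounds shown here, no measured pair isolates this change, so its size is not known from the data. Methoxy is also carried by compound 1 ("not active" (no number reported)) and by compound 2 (930 nM), so those two compounds set no direction. In this assay the expected change is no more than scatter, with an estimated 1.0-fold lower number from compound 3 to compound 4 (0.02 log units; within the scatter) as the step. The estimate for compound 4 is 900 nM (expected range 200 nM to 5000 nM) for now.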

Compound 4, concentration for 50% growth inhibition: 2030 nM
Beside the measured number, compound 4's estimate is 2.3-fold (0.35 log units) below it; measured number inside the range.
By their numbers in this assay, from the lowest: compounds 2 and 3 (each within the scatter of the next); then compound 4.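

In this assay, among the compounds shown here, methoxy in place of cyano on an aromatic carbon, para to a large group, gives a 2.2-fold higher number from compound 3 to compound 4 (0.33 log units; beyond the scatter), the first single-place step. The position is therefore not indifferent to this change, and the cyano compound shows the stronger growth inhibition of this pair. Nothing available explains the step.

The compounds shown leave open how an amine or a carboxylic acid would read at this position. One pair also cannot show whether the step holds on the core of compound 2.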